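Swapping a carbamate for a cyclopropyl amide on a thiophene sulfonamide

A few compounds are considered here, and "the series" means these few. Any claim that something is new, unique, unknown or untested is made for them only; others in the source may bear on it.

Compounds measured so far:
compound 1, `COC(=O)NS(=O)(=O)c1sc(CC(C)C)cc1-c1cccc(Cn2ccnc2)c1`: 3.67 h
compound 2, `CCOC(=O)NS(=O)(=O)c1sc(CC(C)C)cc1-c1cccc(Cn2ccnc2)c1`: 3 h
compound 3, `CC(C)Cc1cc(-c2cccc(Cn3ccnc3)c2)c(S(=O)(=O)NC(=O)OC(C)(C)C)s1`: 0.467 h

All three share one core and differ only in the group on the oxygen next to a carbonyl group. In an ADME assay on microsomes from liver (Mus musculus) for metabolic stability, read by LC-MS, using NADPH, tested at 1 uM (a lower number here means that the compound disappears faster, a higher number that the compound lasts longer), compound 1 gives the highest number of the three. Compound 2 sits close, a 1.2-fold lower number from compound 1 to compound 2 (0.09 log units; within the scatter), a gap that means nothing. Compound 3 is clearly apart: a 7.9-fold lower number from compound 1 to compound 3 (0.90 log units; beyond the scatter) and a 6.4-fold lower number from compound 2 to compound 3 (0.81 log units; beyond the scatter).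

Compound 4, `CC(C)Cc1cc(-c2cccc(Cn3ccnc3)c2)c(S(=O)(=O)NC(=O)C2CC2)s1`, has not yet been tested. It differs from compound 1 in one place: cyclopropyl in place of methoxy on a carbonyl carbon. Among the measured compounds shown here, the oxygen of the carbamate is gone, so none of the measured steps covers exactly this change. The nearest guidance is that methyl and ethyl on that oxygen give similar numbers, whereas tert-butyl gives a modest drop. A cyclopropyl sits between these in carbon count, but it replaces the methoxy rather than growing it, so the measured steps bear only loosely on it. A modest fall from compound 1 is therefore expected, a 1.8-fold lower number from compound 1 to compound 4 (0.26 log units; within the scatter), with wide uncertainty. Compound 4 is estimated at 2 h in this assay, expected to lie between 0.6 h and 6 h.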

Compound 4, half-life: 1.1 h
The estimate for compound 4 lay 1.8-fold (0.26 log units) above the measured number; the range from low to high includes it.
By their numbers in this assay, from the lowest: compound 3; then compound 4; then compounds 2 and 1 (each within the scatter of the next).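

In this assay, the group on the carbonyl carbon matters even when the oxygen is gone: cyclopropyl in place of methoxy lowers the number (a 3.3-fold lower number from compound 1 to compound 4 (0.52 log units; beyond the scatter)), and cyclopropyl in place of ethoxy does the same (a 2.7-fold lower number from compound 2 to compound 4 (0.44 log units; beyond the scatter)). Cyclopropyl in place of tert-butoxy, by contrast, raises it (a 2.4-fold higher number from compound 3 to compound 4 (0.37 log units; beyond the scatter)), so this position is not limited to the two levels seen earlier, one shared by compounds 1 and 2 and a much lower one for compound 3; compound 4 lands on a third level, clear of both. Nothing available here explains why the half-life moves in this way at this position.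

The step from compound 1 to compound 4 removes the oxygen and brings in a ring at once, so the compounds shown cannot tell which of the two changes accounts for the lower number. An open-chain group such as ethyl or isopropyl on the carbonyl carbon, or an amine at the same place, would leave open whether a value near that of compound 4 or one nearer that of compound 1 follows.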